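The source may report more compounds than this note shows. Statements on the series, on what has been measured and on what is new or still open speak of the compounds shown alone.

Measured compounds in a functional assay on MCF7 cells (Homo sapiens) for cytotoxicity, read by MTT assay, with a stated time of 4 days; a lower number here means a stronger inhibitor, a higher number a weaker inhibitor:
- compound 1 `C=C1C[C@]23C[C@@]1(O)CC[C@@H]2c1cccc(C)c1[C@@H]3Cn1cc(-c2ccccn2)nn1`: > 20000 nM, a limit of the assay
- compound 2 `C=C1C[C@]23C[C@@]1(O)CC[C@@H]2c1cccc(C)c1[C@@H]3Cn1cc(-c2ccc(F)cc2)nn1`: > 20000 nM, a limit of the assay

Compound 2 stands only at a limit in this assay; no number is known for it. The same holds for compound 1, whose value is also a limit. Within the data shown here, the one measured step, a step that the two limits leave unreadable from compound 1 to compound 2, is therefore not readable in size or direction. Among the measured compounds shown here, the only evidence on the series is the limit of > 20000 nM in this assay, at which 2 of the 2 values shown sit.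

Compound 3 `C=C1C[C@]23C[C@@]1(O)CC[C@@H]2c1cccc(C)c1[C@@H]3Cn1cc(-c2ccc(C)cc2)nn1` is the next member. Its change from compound 2 is methyl in place of fluoro on an aromatic carbon. For the measured compounds named here, no measured step in this assay bears directly on a methyl in place of a fluoro on that ring; the step from compound 1 to compound 2 is unreadable and gives no guidance. With both measured compounds at the limit, the expectation for compound 3 is that it too will most likely be reported only as a limit, with no step beyond the scatter, which is what a step that the limit leaves unreadable from compound 2 to compound 3 expresses. The estimate for compound 3 in this assay is 30000 nM, within a range from 10000 nM to 100000 nM.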

Compound 3, half-maximal inhibitory concentration: > 20000 nM
Compound 3 ended at the assay's limit; the forecaster's own chance of this, stated with the estimate: 80%; the middle value does not contradict the limit.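

In this assay compound 3 gives > 20000 nM, a limit of the assay. The steps joining compound 3 to compound 1 and to compound 2 therefore cannot be read in size or direction. Still open, going by these compounds, is where the true values of compound 1, compound 2 and compound 3 lie, and whether 4-methylphenyl, 4-fluorophenyl and pyridin-2-yl differ at all in this assay.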